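Cyano on the Ethoxypyridine Ring: Expected Outcome for Compound 4

This account rests on a few compounds, and the source may have more. Where it says the series, first, only, none or still open, it means among the compounds named here.

Compound 1 `CCOc1cccnc1Nc1cccc(C)n1` gives 40 nM in an assay on Ltk cells with metabotropic glutamate receptor 5 (Homo sapiens) as the target, read by fluorescence and calcium flux; a lower number here means a stronger inhibitor, a higher number a weaker inhibitor.
Compound 2 `CCOc1cccnc1Nc1cccc(C(=O)OC)n1` gives 6200 nM in this assay.
Compound 3 `CCCOc1cccnc1Nc1cccc(C)n1` gives 1600 nM in this assay.

Among these three, compound 1 has the lowest number in this assay, and both neighbours sit well beyond the scatter: a 40-fold higher number from compound 1 to compound 3 (1.60 log units; beyond the scatter) and a 160-fold higher number from compound 1 to compound 2 (2.19 log units; beyond the scatter). Compound 4 `CCOc1cc(C#N)cnc1Nc1cccc(C)n1` differs from compound 1 by cyano in place of hydrogen on an aromatic carbon.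

Neither measured step touches the same position. The step of a 160-fold higher number from compound 1 to compound 2 (2.19 log units; beyond the scatter) changed a group on the other ring, and the step of a 40-fold higher number from compound 1 to compound 3 (1.60 log units; beyond the scatter) lengthened the ethoxy chain; each was large and each raised the number. Among the measured compounds shown here, what the two steps show together is only that compound 1 has not tolerated any change yet, and that lesson is indirect for a cyano group placed where none of the measured compounds carries a substituent. On that basis a modest rise in this assay is expected for compound 4, smaller than either measured step, with real uncertainty in both directions. Compound 4 is estimated at 120 nM, within 20 nM to 700 nM, which would mean an expected step of a 3.0-fold higher number from compound 1 to compound 4 (0.48 log units; beyond the scatter).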

Compound 4, half-maximal inhibitory concentration: 46 nM
Estimate against measurement, compound 4: 2.6-fold (0.42 log units) above; the range from low to high includes it.
By their numbers in this assay, from the lowest: compounds 1 and 4 (each within the scatter of the next); then compound 3; then compound 2.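

In this assay, the step of a 1.2-fold higher number from compound 1 to compound 4 (0.06 log units; within the scatter) is the first single change among the compounds shown that stays within the scatter, so compound 4 and compound 1 cannot be told apart by their numbers. This sets the aromatic carbon two atoms from the ring nitrogen, meta to the ethoxy group, apart from the two places changed earlier, where the steps of a 160-fold higher number from compound 1 to compound 2 (2.19 log units; beyond the scatter) and a 40-fold higher number from compound 1 to compound 3 (1.60 log units; beyond the scatter) both lie beyond the scatter; compound 1 can therefore carry an added cyano at this carbon with no measurable cost in this assay. No measurement shown here accounts for this result or for the contrast with the two earlier steps.

As far as these compounds go, a single substituent does not define what this carbon accepts, so it remains open whether a methyl, a chlorine, an amine or a carboxylic acid there would also stay within the scatter of compound 1. From the compounds shown here alone, it is equally open whether cyano at this carbon would behave the same way on the longer chain of compound 3 or with the methoxycarbonyl group of compound 2.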